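Series notes: hydroxy in place of phenyl on the piperidine

This account rests on a few compounds, and the source may have more. Where it says the series, first, only, none or still open, it means among the compounds named here.

Compound 2 `CC(C(=O)NCc1ccc(C(F)(F)F)nc1N1CCC(c2ccccc2)CC1)c1ccc(NS(C)(=O)=O)c(F)c1` gives 25 nM in a functional assay on CHO-K1 cells for antagonist activity at transient receptor potential cation channel subfamily V member 1 (Homo sapiens), read by FLIPR (on this read-out lower numbers stand for stronger inhibition and higher numbers for weaker inhibition), the lowest number of the two measured; compound 1 `CC(C(=O)NCc1ccc(C(F)(F)F)nc1NC1CCCCC1)c1ccc(NS(C)(=O)=O)c(F)c1` gives 260 nM. Among the compounds with values here, the single measured step, a 10-fold lower number from compound 1 to compound 2 (1.02 log units; beyond the scatter), exchanged the whole ring on the aromatic carbon rather than a group on that ring, so it bears only loosely on the next change. Compound 3 `CC(C(=O)NCc1ccc(C(F)(F)F)nc1N1CCC(O)CC1)c1ccc(NS(C)(=O)=O)c(F)c1` carries hydroxy in place of phenyl on a saturated ring carbon. Within the data shown here, no measured pair shows this difference directly, and the large gain of that step is the only pointer. For compound 3 a weaker result is expected, a step of a 16-fold higher number from compound 2 to compound 3 (1.20 log units; beyond the scatter), with an estimate of 400 nM and a range from 100 nM to 1500 nM.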

Compound 3, half-maximal inhibitory concentration: "not active" (no number reported)
For compound 3 the study gives words and no number; there is nothing to compare the estimate with.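

Within the data shown here, compound 3 is reported only as not active, without a number, so no step from compound 2 to compound 3 can be read. Nothing shown accounts for this result. The compounds shown leave open the size of the change with hydroxy in place of phenyl.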